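Methyl added to compound 3: expected step

A few compounds are considered here, and "the series" means these few. Any claim that something is new, unique, unknown or untested is made for them only; others in the source may bear on it.

The series shares one core, seen in compound 1 (`O=C(CCc1cccc2c1B(O)OC2)Nc1ccc(I)cc1`), compound 2 (`Cc1ccc(NC(=O)CCc2cccc3c2B(O)OC3)cc1`) and compound 3 (`O=C(CCc1cccc2c1B(O)OC2)Nc1cccc(Br)c1`). In a functional assay on SK-OV-3 cells (Homo sapiens) for antiproliferative activity, read by MTT assay, with a stated time of 72 h (on this read-out lower numbers stand for stronger inhibition and higher numbers for weaker inhibition), compound 1 gives 51000 nM, compound 2 gives 860 nM and compound 3 gives 540 nM. Compound 3 stands with compound 2 at the low end of these numbers, the gap being a 1.6-fold lower number from compound 2 to compound 3 (0.20 log units; within the scatter). Compound 1 lies far off, with a 94-fold lower number from compound 1 to compound 3 (1.98 log units; beyond the scatter).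

Compound 4 (`Cc1ccc(NC(=O)CCc2cccc3c2B(O)OC3)cc1Br`) arises by methyl in place of hydrogen on an aromatic carbon, ortho to a bromo group and para to a large group. It thus carries the methyl of compound 2 together with the bromo of compound 3. Since a 1.6-fold lower number from compound 2 to compound 3 (0.20 log units; within the scatter) stays small, no large step is expected from combining them. The exchange of iodo for methyl, a 59-fold lower number from compound 1 to compound 2 (1.77 log units; beyond the scatter), shows that single changes here can be large, so the range is kept wide on the upper side.

The estimated change is a 1.2-fold higher number from compound 3 to compound 4 (0.08 log units; within the scatter), expected to stay within the scatter. Compound 4 is expected at 650 nM, with an estimated range of 220 nM to 2500 nM.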

Compound 4, half-maximal inhibitory concentration: 600 nM
Compound 4: the middle estimate sits 1.1-fold (0.03 log units) above what was measured, and the stated range covers the measured number.
By their numbers in this assay, from the lowest: compounds 3, 4 and 2 (each within the scatter of the next); then compound 1.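

In this assay, methyl in place of hydrogen on an aromatic carbon, ortho to a bromo group and para to a large group, gives a 1.1-fold higher number from compound 3 to compound 4 (0.05 log units; within the scatter), so a methyl at this position is tolerated on a ring that already carries bromo. Seen from the other side, the added bromo gives a 1.4-fold lower number from compound 2 to compound 4 (0.16 log units; within the scatter), so neither single change moves the number beyond the scatter, and the two groups together sit level with each alone. Nothing available here bears on why these steps stay so small.

As far as these compounds go, it remains open whether an amine, a carboxylic acid or a longer chain at this position would stay as close to compound 3. Also open, from the compounds shown here alone, is whether a methyl here would stay as quiet in the iodo series of compound 1, where a 59-fold lower number from compound 1 to compound 2 (1.77 log units; beyond the scatter) marks a far larger step.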